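Remote Swap at the Quinoline Periphery: From Aryl Ether to Alkyl

The source may hold more compounds than are shown below. What is called first, only, known or untested is meant among the compounds shown, and "the series" means these compounds.

Three compounds have been measured in a physicochemical assay for acid dissociation:

Compound 1, `COc1cccc(CNCCCNc2ccnc3cc(Oc4ccc(Cl)cc4)ccc23)c1O`, gives 9.28.
Compound 2, `COc1ccc(F)cc1CNCCCNc1ccnc2cc(C3CCCCC3)ccc12`, gives 9.47.
Compound 3, `Fc1ccc(-c2ccc3c(NCCCNCc4ccco4)ccnc3c2)cc1`, gives 9.47.

The values of compound 1 differ from those of compound 2 and compound 3 by amounts that fall within the usual scatter of repeated measurements in this assay, so on these numbers the three compounds cannot be told apart. For the measured compounds named here, no pair of them differs in a single place, so no measured step is available to guide expectations.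

The next compound is compound 4, `COc1cccc(CNCCCNc2ccnc3cc(CCC(C)C)ccc23)c1O`, which has not yet been measured in this assay. Compared with compound 1 the change is isopentyl in place of 4-chlorophenoxy on an aromatic carbon. The change sits on the fused ring system, away from the nitrogen atoms that the read-out of this assay reflects, and the three measured compounds, which carry three quite different groups at this position, all return numbers within scatter of one another.

For compound 4 the estimate is therefore 9.4, with a range from 9.1 to 9.7. The step from compound 1 to compound 4 is thus expected to be a number 0.12 log units higher from compound 1 to compound 4 (within the scatter), a shift that is not expected to exceed the scatter.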

Compound 4, acid dissociation constant: 9.47
For compound 4 the middle estimate is 0.07 log units below the measured one; low and high end bracket the measured number.
By their numbers in this assay, from the lowest: compounds 1, 2, 3 and 4 (each within the scatter of the next).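

In this assay, for the compounds shown here, the exchange of 4-chlorophenoxy for isopentyl provides the first readable step at this position, with a number 0.19 log units higher from compound 1 to compound 4 (within the scatter) and the rest of the structure held constant. The earlier compounds shown here differed in more than one place and could only suggest that this position has little bearing on the read-out, whereas this pair tests that directly: removing the six-membered aromatic ring of carbon only, the chlorine and the oxygen leaves compound 4 at 9.47, which cannot be told apart from compound 1 at 9.28 in this read-out. No measurement shown here offers an explanation for this outcome.

Going by these compounds alone, the pair covers only two neutral groups at this position, so it remains open whether an amine or a carboxylic acid on the same aromatic carbon would also leave the number within the scatter. Going by these compounds, it is equally open whether a change elsewhere in the shared core, such as a longer chain joining the two nitrogen atoms, would give a step beyond the scatter in this assay.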